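Dichlorophenyl Analogue and Its Expected Cytotoxicity Outcome

The source may hold more compounds than are shown below. What is called first, only, known or untested is meant among the compounds shown, and "the series" means these compounds.

Compound 2 `Cc1cc(-c2ccc(Cl)cc2)cc(C)c1Nc1ccnc(Nc2ccc(C#N)cc2)n1` gives 4190 nM in an ADME assay on MT4 cells (Homo sapiens) for cytotoxicity, read by MTT assay, with a stated time of 4 days; on this read-out higher numbers stand for lower toxicity in this test and lower numbers for higher toxicity in this test; compound 1 `Cc1cc(-c2ccc(F)cc2)cc(C)c1Nc1ccnc(Nc2ccc(C#N)cc2)n1` gives 4170 nM, and the two numbers sit together, since a 1.0-fold higher number from compound 1 to compound 2 (0.00 log units; within the scatter) lies within the scatter. Compound 3 `Cc1cc(-c2cc(Cl)cc(Cl)c2)cc(C)c1Nc1ccnc(Nc2ccc(C#N)cc2)n1` differs from compound 2 by 3,5-dichlorophenyl in place of 4-chlorophenyl on an aromatic carbon. Within the data shown here, only one measured step, chloro in place of fluoro on an aromatic carbon, bears on a change at this position, and it moved nothing beyond the scatter. For compound 3 a step of a 1.2-fold lower number from compound 2 to compound 3 (0.08 log units; within the scatter) is therefore expected, with little movement in this assay. Compound 3 is estimated at 3500 nM, in a range from 1500 nM to 8000 nM.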

Compound 3, half-maximal cytotoxic concentration: 4290 nM
Compound 3: the middle estimate sits 1.2-fold (0.09 log units) below what was measured, and the stated range covers the measured number.
By their numbers in this assay, from the lowest: compounds 1, 2 and 3 (each within the scatter of the next).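

Moving from one halogen to two on this aryl group leaves the read-out of this assay level: 3,5-dichlorophenyl in place of 4-chlorophenyl gives (a 1.0-fold higher number from compound 2 to compound 3 (0.01 log units; within the scatter)), and in place of 4-fluorophenyl gives (a 1.0-fold higher number from compound 1 to compound 3 (0.01 log units; within the scatter)). The position therefore takes a second chlorine and a different substitution pattern on the ring, not only a swap of one halogen for another, without a step beyond the scatter. Nothing measured here accounts for these numbers staying together.

The compounds shown carry only fluoro or chloro on this ring. Going by these compounds, whether an amine or a carboxylic acid there would leave the number in the same place stays open.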